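The source may report more compounds than this note shows. Statements on the series, on what has been measured and on what is new or still open speak of the compounds shown alone.

In a functional assay on K562 cells (Homo sapiens) for inhibition, read by MTT assay, with a stated time of 24 h (a higher number here means a weaker inhibitor, a lower number a stronger inhibitor), compound 1 (`CCOC1c2cc(OCc3cc(C)cc(C)c3)c(OCc3cc(C)cc(C)c3)cc2CCN1C(=O)OC(C)(C)C`) gives > 20000 nM, which is a limit and not a number. Compound 2 (`CC[C@@H]1CC(=O)C/C=C(/C)[C@H]2c3cc(OCc4ccccc4)c(OCc4ccccc4)cc3CCN12`) gives > 20000 nM, again a limit. The two measured compounds therefore share one mark: the limit of > 20000 nM in this assay, at which 2 of the 2 values shown sit. For the measured compounds named here, neither yields a number, and no measured step is available to gauge a change against.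

Compound 3 (`Cc1cc(C)cc(COc2cc3c(cc2OCc2cc(C)cc(C)c2)CN(C(=O)OC(C)(C)C)CC3)c1`) departs from compound 1 in one place, with hydrogen in place of ethoxy on a saturated ring carbon. The expectation rests on compound 1, whose reading of > 20000 nM is a limit. The expected step that the limit leaves unreadable from compound 1 to compound 3 is none beyond the scatter, in either direction. Compound 3 is estimated at 25000 nM, with an expected range of 10000 nM to 50000 nM, and this assay may well report only a limit again.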

Compound 3, half-maximal inhibitory concentration: > 20000 nM
Compound 3 gave a limit, no number; the forecaster's own chance of this, stated with the estimate: 75%; the middle value does not contradict the limit.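

Compound 1 and compound 3 both stop at a limit in this assay, so no step can be read for hydrogen in place of ethoxy. The compounds shown leave open which change to the shared core, if any, would give a measured number.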